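Thioether side-chain variation on the shared core: notes

The source may report more compounds than this note shows. Statements on the series, on what has been measured and on what is new or still open speak of the compounds shown alone.

Measured so far:
compound 1, `Cc1cc(Nc2cc(-c3ccccc3)[nH]n2)n2nc(SCCCc3ccccc3)nc2n1`, in an ADME assay on GES1 cells (Homo sapiens) for inhibition, read by MTT assay, with a stated time of 72 h (a higher number here means a weaker inhibitor, a lower number a stronger inhibitor), compound 1 gives 40200 nM
compound 2, `Cc1cc(Nc2cc(-c3ccccc3)[nH]n2)n2nc(SCCc3ccccc3)nc2n1`, compound 2 gives 37400 nM
compound 3, `Cc1cc(Nc2cc(-c3cccs3)[nH]n2)n2nc(SCc3ccc(Br)cc3)nc2n1`, compound 3 gives 38700 nM

Compound 1 carries the highest of the three numbers, yet its gaps to compound 3 and to compound 2 are both within the scatter, so no ordering among the three is supported. The unmeasured compound 4, `Cc1cc(Nc2cc(-c3ccccc3)[nH]n2)n2nc(SCc3ccc(Br)cc3)nc2n1`, differs from compound 1 by 4-bromophenyl in place of phenethyl on a saturated chain carbon bound to a sulfur. For the measured compounds named here, the one measured step of the same kind, a shortening of this chain, gave a 1.1-fold lower number from compound 1 to compound 2 (0.03 log units; within the scatter). The (4-bromobenzyl)sulfanyl chain of compound 4 is also present in compound 3, and compound 3 gives 38700 nM. Nothing here points to a move beyond the scatter. Compound 4 is therefore expected near 38000 nM, between 20000 nM and 72000 nM, an estimated step of a 1.1-fold lower number from compound 1 to compound 4 (0.02 log units; within the scatter).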

Compound 4, half-maximal inhibitory concentration: 39300 nM
Beside the measured number, compound 4's estimate is 1.0-fold (0.01 log units) below it; measured number inside the range.
By their numbers in this assay, from the lowest: compounds 2, 3, 4 and 1 (each within the scatter of the next).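

In this assay, 4-bromophenyl on a saturated chain carbon bound to a sulfur gives a value within the scatter of both the phenethyl and the shorter chain (a 1.0-fold lower number from compound 1 to compound 4 (0.01 log units; within the scatter); a 1.1-fold higher number from compound 2 to compound 4 (0.02 log units; within the scatter)). The second place, where phenyl stands in place of thiophen-2-yl on an aromatic carbon, now also reads within the scatter (a 1.0-fold higher number from compound 3 to compound 4 (0.01 log units; within the scatter)). No supporting data bear on this result.

Still open, on these data alone, is whether an amine or a carboxylic acid at the end of the thioether chain would move the number beyond the scatter. As far as these compounds go, a chain longer than 3-phenylpropyl also remains open.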